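Compound 3 to compound 4: a step among limits

A few compounds are considered here, and "the series" means these few. Any claim that something is new, unique, unknown or untested is made for them only; others in the source may bear on it.

Measured in a functional assay on Caco-2 cells (Homo sapiens) for antiproliferative activity, read by MTT assay, with a stated time of 48 h; on this read-out higher numbers stand for weaker inhibition and lower numbers for stronger inhibition:
- compound 1 `C=CCN(C)C(=O)c1ccc(C(CC)(CC)c2ccc(OCCC(O)(CC)CC)c(C)c2)n1CC`: > 50000 nM (a limit)
- compound 2 `C#CC(C)OC(=O)c1ccc(C(CC)(CC)c2ccc(OCCC(O)(CC)CC)c(C)c2)n1CC`: > 50000 nM (a limit)
- compound 3 `CCC(C)C(NC(=O)c1ccc(C(CC)(CC)c2ccc(OCCC(O)(CC)CC)c(C)c2)n1CC)C(=O)OC`: > 50000 nM (a limit)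

In this assay compound 3 gives > 50000 nM, which is a limit and not a number. It has the same standing as the other two measured compounds: the limit of > 50000 nM in this assay, at which 3 of the 3 values shown sit.

The next compound is compound 4 `CCOC(=O)C(CC(=O)OC)NC(=O)c1ccc(C(CC)(CC)c2ccc(OCCC(O)(CC)CC)c(C)c2)n1CC`, and the change from compound 3 is a group of 11 heavy atoms (7 carbon, 4 oxygen; no ring) in place of a group of 9 heavy atoms (7 carbon, 2 oxygen; no ring), on an amide-type nitrogen.

Within the data shown here, three measured steps bear on this change, though all of them lie on a carbonyl carbon rather than on an amide-type nitrogen. They are a step that the two limits leave unreadable from compound 1 to compound 2, a step that the two limits leave unreadable from compound 1 to compound 3 and a step that the two limits leave unreadable from compound 2 to compound 3. None of them has a readable size, so none supplies a size to carry over. No step beyond the scatter is expected in either direction, and the expected step is a number no higher from compound 3 to compound 4 (the limit leaves the size open).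

Compound 4 is estimated at 50000 nM, with an expected range from 20000 nM to 100000 nM.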

Compound 4, half-maximal inhibitory concentration: 3020 nM
The estimate for compound 4 lay 17-fold (1.22 log units) above the measured number, outside the stated range (below it).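

In this assay, changing the group on the amide-type nitrogen moves the series off its limit, with an at least 16-fold lower number from compound 3 to compound 4 (1.21 log units; beyond the scatter). Compound 4 also stands apart when the whole group on the carbonyl carbon is compared, with an at least 16-fold lower number from compound 2 to compound 4 (1.21 log units; beyond the scatter) and with an at least 16-fold lower number from compound 1 to compound 4 (1.21 log units; beyond the scatter). Among these compounds, the steps among compound 1, compound 2 and compound 3 cannot be read, so these are the first readable sizes, and compound 4 alone has a number: the limit of > 50000 nM in this assay, at which 3 of the 4 values shown sit.

As far as these compounds go, the full size of each step stays open, as one end of each is a limit. Also open, from the compounds shown here alone, is which part of the entering group carries the step, and whether a carboxylic acid in place of either ester, or a longer chain, would keep it.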